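Swapping an anilino group for a pyridylmethylamino one

This account rests on a few compounds, and the source may have more. Where it says the series, first, only, none or still open, it means among the compounds named here.

Compound 2 `Cc1nc(Nc2ccccc2)nc(N[C@@H]2C[C@H](CO)[C@@H](O)[C@H]2O)c1-c1nc2ccccc2s1` is measured in an ADME assay on the whole organism (plasma) for pharmacokinetics, with Rattus norvegicus as the target, with a stated time of 6 h, at a dose of 10 mg/kg by the oral route (a higher number here means more compound in the circulation at the dose given, a lower number less compound in the circulation), at 742 ng.h/mL. For the measured compounds named here, compound 1 `Cc1nc(NCCOC(C)C)nc(N[C@@H]2C[C@H](CO)[C@@H](O)[C@H]2O)c1-c1nc2ccccc2s1` gives 426 ng.h/mL, and the only known step, a 1.7-fold higher number from compound 1 to compound 2 (0.24 log units; within the scatter), sits within the scatter, so the two numbers cannot be ranked. Compound 3 `Cc1nc(NCc2ccncc2)nc(N[C@@H]2C[C@H](CO)[C@@H](O)[C@H]2O)c1-c1nc2ccccc2s1` carries the change ((pyridin-4-yl)methyl in place of phenyl on a nitrogen on an aromatic ring). Going by the values given here, no measured step covers this change; the one known step shows that altering this position left the number within the scatter. The expected step is therefore a 1.6-fold lower number from compound 2 to compound 3 (0.22 log units; within the scatter), modest and downward at most. Compound 3 is estimated at 450 ng.h/mL, with a range from 150 ng.h/mL to 1300 ng.h/mL.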

Compound 3, area under the concentration-time curve: 47.9 ng.h/mL
Estimate against measurement, compound 3: 9.4-fold (0.97 log units) above; the measured number lies below the stated range.
By their numbers in this assay, from the lowest: compound 3; then compounds 1 and 2 (each within the scatter of the next).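

In this assay the group on this nitrogen turns out to matter: (pyridin-4-yl)methyl in place of phenyl gives a 15-fold lower number from compound 2 to compound 3 (1.19 log units; beyond the scatter) and, set against the 2-isopropoxyethyl chain, gives an 8.9-fold lower number from compound 1 to compound 3 (0.95 log units; beyond the scatter) for the same group. Compound 1 and compound 2 could not be told apart, yet each stands clearly apart from compound 3. No measurement at hand explains this.

Still open, from the compounds shown here alone, is whether the ring nitrogen or the extra carbon link goes with the lower number. A benzyl group would separate the two.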